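Removing ethyl from the butyl chain of compound 1

The source may hold more compounds than are shown below. What is called first, only, known or untested is meant among the compounds shown, and "the series" means these compounds.

Measured so far in a physicochemical assay for lipophilicity, read by HPLC, using the shake flask method (on this read-out higher numbers stand for higher lipophilicity and lower numbers for lower lipophilicity), are
- compound 1 `CCCCN(Cc1ccc(Cl)nc1)/C(C)=N/C#N` at 2.13
- compound 2 `CCCC/C(=N\C#N)N(C)Cc1ccc(Cl)nc1` at 1.87
- compound 3 `CC(C)C/C(=N\C#N)N(C)Cc1ccc(Cl)nc1` at 1.75

Compound 1 at 2.13 stands above compound 3 by more than the scatter, but it lies within the scatter of compound 2. Compound 4 `CCN(Cc1ccc(Cl)nc1)/C(C)=N/C#N` has not yet been measured. It differs from compound 1 by hydrogen in place of ethyl on a saturated chain carbon, two bonds along the chain from an amine nitrogen and the same difference, cut one bond further out, reads butyl to ethyl.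

Among the measured compounds shown here, the only measured step that differs in one place is a number 0.12 log units lower from compound 2 to compound 3 (within the scatter) with isopropyl in place of propyl, and it stays within the scatter. That step rearranges a chain and does not shorten it, so it gives only weak guidance here. For the measured compounds named here, no measured step takes ethyl away, and the size expected below is a judgement from the structural change with no direct precedent. Starting from compound 1 at 2.13 a lower number is expected in this assay by clearly more than the scatter. The estimated change is a number 0.83 log units lower from compound 1 to compound 4 (beyond the scatter) as a working expectation.

For compound 4 the estimated value is 1.3 with an expected range from 1 to 1.6 on this read-out.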

Compound 4, partition coefficient: 1.19
Beside the measured number, compound 4's estimate is 0.11 log units above it; the measured number falls inside the stated range.
By their numbers in this assay, from the lowest: compound 4; then compounds 3, 2 and 1 (each within the scatter of the next, the first and the last beyond it).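

Hydrogen in place of ethyl on a saturated chain carbon, two bonds along the chain from an amine nitrogen, gives a number 0.94 log units lower from compound 1 to compound 4 (beyond the scatter) in this assay and so marks the first one-place step in the series to leave the scatter, while the rearrangement of propyl to isopropyl, a number 0.12 log units lower from compound 2 to compound 3 (within the scatter) on the same read-out, stays inside it. Shortening the chain at this position therefore moves the number clearly where rearranging a chain elsewhere on the core did not, and the change involves carbon alone, with no ring, no hydrogen-bond donors or acceptors and no net charge among the atoms that leave. Nothing in hand accounts for the size of this step.

The compounds shown hold butyl and ethyl at this position, which leaves open whether the number falls evenly with chain length or mostly at one point, something propyl and methyl would settle. Also open, as far as these compounds go, is whether a longer chain, a branched chain such as isobutyl, a cyclopropylmethyl group or a chain ending in a hydroxyl group would follow the same course.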